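A few compounds are considered here, and "the series" means these few. Any claim that something is new, unique, unknown or untested is made for them only; others in the source may bear on it.

Measured in a physicochemical assay for solubility, read by HPLC; on this read-out higher numbers stand for higher solubility and lower numbers for lower solubility:
- compound 1 `O=C(CC1CCCCC1)N1CCN(c2nc(=O)c3cc(C(F)(F)F)cc([N+](=O)[O-])c3s2)CC1`: 0.12 ug/mL
- compound 2 `O=C(c1ccccc1Cl)N1CCN(c2nc(=O)c3cc(C(F)(F)F)cc([N+](=O)[O-])c3s2)CC1`: 8.18 ug/mL
- compound 3 `O=C(C1CCCC1)N1CCN(c2nc(=O)c3cc(C(F)(F)F)cc([N+](=O)[O-])c3s2)CC1`: 5.34 ug/mL

Compound 3 sits close to compound 2, a 1.5-fold lower number from compound 2 to compound 3 (0.19 log units; within the scatter), and far from compound 1, a 45-fold higher number from compound 1 to compound 3 (1.65 log units; beyond the scatter). Compound 4 `CC(C)(C)C1CCC(C(=O)N2CCN(c3nc(=O)c4cc(C(F)(F)F)cc([N+](=O)[O-])c4s3)CC2)CC1` differs from compound 3 by 4-(tert-butyl)cyclohexyl in place of cyclopentyl on a carbonyl carbon. Among the compounds with values here, the only step touching a change of this kind is a 45-fold higher number from compound 1 to compound 3 (1.65 log units; beyond the scatter), where a saturated ring group with fewer carbons replaced a larger one and the number rose strongly; the present step runs the other way and enters a larger saturated ring group. A large step downward in this assay is therefore expected, a 53-fold lower number from compound 3 to compound 4 (1.73 log units; beyond the scatter). For compound 4 the estimate is 0.1 ug/mL, range 0.02 ug/mL to 0.6 ug/mL.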

Compound 4, solubility: < 0.1 ug/mL
Compound 4: a limit, no number; the forecaster's own chance of this, stated with the estimate: 20%; the middle value sits exactly at the limit.
By their numbers in this assay, from the lowest: compound 1; then compounds 3 and 2 (each within the scatter of the next). At a limit, below all of these: compound 4.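

In this assay compound 4 gives < 0.1 ug/mL, which is a limit and not a number. On a carbonyl carbon, 4-(tert-butyl)cyclohexyl in place of cyclopentyl gives a large step down, an at least 53-fold lower number from compound 3 to compound 4 (1.72 log units; beyond the scatter), and 4-(tert-butyl)cyclohexyl in place of 2-chlorophenyl gives another large step down, an at least 81-fold lower number from compound 2 to compound 4 (1.91 log units; beyond the scatter). With cyclohexylmethyl as the group replaced, the step is an at least 1.2-fold lower number from compound 1 to compound 4 (0.07 log units; that floor lies within the scatter), which leaves open how those two compounds compare.

Plain cyclohexyl at this place would separate the ring change from the tert-butyl group, and that comparison stays open. From the compounds shown here alone, what an amine or a carboxylic acid on the ring would give also stays open.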